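A few compounds are considered here, and "the series" means these few. Any claim that something is new, unique, unknown or untested is made for them only; others in the source may bear on it.

Working notes on the series. Compound 1 `Fc1ccc(F)c(/N=N/c2ccc(NC[C@@H]3CCCN4CCCC[C@H]34)c3c2CCCC3)c1`, compound 2 `c1ccc(/N=N/c2ccc(NC[C@@H]3CCCN4CCCC[C@H]34)c3c2CCCC3)cc1` and compound 3 `CN(C)CCCN(/N=N/c1ccccc1)c1cccc(C(F)(F)F)c1` have been measured; compound 4 `CN(C)CCCN(/N=N/c1cc(F)ccc1F)c1cccc(C(F)(F)F)c1` has not. In an ADME assay on Vero cells (Chlorocebus sabaeus) for cytotoxicity, read by crystal violet staining (a higher number here means that more compound is tolerated, a lower number that less compound is tolerated), compound 2 gives 80000 nM and compound 1 gives 80000 nM. The change from compound 2 to compound 1 is 2,5-difluorophenyl in place of phenyl on a double-bonded nitrogen, and it made no change at the digits printed from compound 2 to compound 1 (within the scatter). In this assay compound 3 gives 20000 nM, the lowest of the three numbers and beyond the scatter from both compound 1 and compound 2. The difference between the core of compound 3 and the core of compound 2 is not broken down here.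

Compound 4 carries the same change relative to compound 3, namely (2,5-difluorophenyl in place of phenyl on a double-bonded nitrogen), at a place described in the same words as for the pair compound 2 and compound 1. The step from compound 3 to compound 4 in this assay is expected to be no change at the digits printed from compound 3 to compound 4 (within the scatter). That expectation rests on compound 2 and compound 1, where the same change gave no change at the digits printed from compound 2 to compound 1 (within the scatter). For compound 4 the value in this assay is estimated at 20000 nM, with a range from 10000 nM to 45000 nM.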

Compound 4, half-maximal cytotoxic concentration: 30000 nM
The estimate for compound 4 lay 1.5-fold (0.18 log units) below the measured number, and the stated range covers the measured number.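

In this assay the replacement of phenyl by 2,5-difluorophenyl on a double-bonded nitrogen gives a 1.5-fold higher number from compound 3 to compound 4 (0.18 log units; within the scatter) and so leaves the reading of the core of compound 3 unresolved from that of its parent, as it did on the core of compound 2. Within this pair of cores the change carries over without a detectable difference between the two steps: the same change on two cores in this assay, no change at the digits printed (within the scatter) from compound 2 to compound 1 and a 1.5-fold higher number (0.18 log units; within the scatter) from compound 3 to compound 4, 1.5-fold (0.18 log units) apart, within the scatter of two such steps. Within the data shown here, this shows only that the change stayed within the scatter on two cores in one assay; it does not show that the same would hold on a third core, and it does not separate the contribution of either fluorine.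

The compounds shown leave open what a single fluorine, a chlorine or a methoxy group on that phenyl ring would do in this assay. They also leave open how an amine or a carboxylic acid in that ring's place would read, on either core.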